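Fluoro in place of hydrogen on compound 3

The compounds below may be only part of what the source reports. "The series", "measured", "known", "first", "only" and "open" are said of these compounds alone.

Compound 1 `Cc1c(Cc2c(Cl)cccc2Cl)nc(SCC(=O)c2ccc(F)cc2)[nH]c1=O` gives > 57000 nM
Compound 2 `O=C(CSc1nc(Cc2c(F)cccc2Cl)cc(=O)[nH]1)c1ccc(F)cc1` gives > 61000 nM
Compound 3 `Cc1c(Cc2c(F)cccc2Cl)nc(SCC(=O)c2ccccc2)[nH]c1=O` gives > 12000 nM

All three compounds were tested in an ADME assay on MT4 cells (Homo sapiens) for cytotoxicity, read by MTT assay (a higher number here means that more compound is tolerated, a lower number that less compound is tolerated), and each result is a limit, not a number. Compound 3 therefore stands only on its limit of > 12000 nM in this assay and has no exact value. Compound 4 `Cc1c(Cc2c(F)cccc2Cl)nc(SCC(=O)c2ccc(F)cc2)[nH]c1=O` is compound 3 with fluoro in place of hydrogen on an aromatic carbon, para to a large group, which turns phenyl to 4-fluorophenyl fluoro in place of hydrogen on an aromatic carbon in the structure. Among the compounds with values here, no two measured compounds differ in one place, so no direct example of this step exists. Compound 1 carries the 4-fluorophenyl group, and its > 57000 nM is a limit. Compound 2 also carries that group, and its > 61000 nM is likewise a limit. On these two limits, an estimated step that the limit leaves unreadable from compound 3 to compound 4 is expected, toward more compound tolerated. For compound 4 the estimated value is 35000 nM and is expected to fall from 10000 nM to 70000 nM in a measurement that may well report only a limit.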

Compound 4, half-maximal cytotoxic concentration: > 59000 nM
Compound 4 was reported as a limit; the forecaster's own chance of this, stated with the estimate: 85%; middle value at least 1.6-fold (0.22 log units) from the limit.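

Within the data shown here, compound 4 is reported only as a limit in this assay, as are compound 1, compound 2 and compound 3, so no step to compound 4 can be read. The compounds shown leave open how far fluoro in place of hydrogen, methyl in place of hydrogen or fluoro in place of chloro shifts the half-maximal cytotoxic concentration.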